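Swapping the sulfonamide arm of a piperidine ester for an amide

The source may report more compounds than this note shows. Statements on the series, on what has been measured and on what is new or still open speak of the compounds shown alone.

Measured compounds:
Compound 1 `CCCN(CCC)S(=O)(=O)c1ccc(S(=O)(=O)N2CCC[C@@H](C(=O)OCC)C2)cc1`, 600 nM
Compound 2 `CC(C)NS(=O)(=O)c1ccc(S(=O)(=O)N2CCC[C@@H](C(=O)N3CCN(c4nc(C(C)C)no4)CC3)C2)cc1`, 200 nM

Both compounds were tested in a functional assay on MIA PaCa-2 cells (Homo sapiens) for inhibition, read by MTT assay, with a stated time of 3 days; a higher number here means a weaker inhibitor, a lower number a stronger inhibitor. Compound 1 gives 600 nM, the higher of the two numbers, while compound 2 gives 200 nM, a lower number that lies beyond the usual scatter. Among the measured compounds shown here, the two compounds differ in several places at once, so their values show only that compound 2 is the stronger inhibitor here.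

Compound 3 `CCOC(=O)[C@@H]1CCCN(S(=O)(=O)c2ccc(C(=O)N(CC)CC)cc2)C1` keeps the core of compound 1 and changes one group: diethylcarbamoyl in place of dipropylsulfamoyl on an aromatic carbon. For the measured compounds named here, nothing measured so far isolates this change, so the expectation rests on the size of the group alone. The step from compound 1 to compound 3 is expected to be a 1.7-fold higher number from compound 1 to compound 3 (0.22 log units; within the scatter), toward a weaker inhibitor. Compound 3 is therefore estimated at 1000 nM, within a range from 300 nM to 3000 nM.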

Compound 3, half-maximal inhibitory concentration: 100 nM
For compound 3 the middle estimate is 10-fold (1.00 log units) above the measured one; the whole stated range lies above it.
By their numbers in this assay, from the lowest: compounds 3 and 2 (each within the scatter of the next); then compound 1.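

Among the compounds shown here, at the aromatic carbon para to a large group, compound 3 gives the first comparison of compounds that differ in one place: in this assay, diethylcarbamoyl in place of dipropylsulfamoyl gives a 6.0-fold lower number from compound 1 to compound 3 (0.78 log units; beyond the scatter), toward a stronger inhibitor. The change at this position therefore matters for this read-out, and the dipropylsulfamoyl group is not required there, even though the group that replaces it has fewer heavy atoms. No measured evidence bears on why the step occurs.

This step changes the linking group and the alkyl chains together, so it remains open which of them accounts for the difference; a dipropylcarbamoyl or a diethylsulfamoyl group would separate the two. As far as these compounds go, it also remains open how a carboxylic acid or a simple amine would fare at this position.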